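A few compounds are considered here, and "the series" means these few. Any claim that something is new, unique, unknown or untested is made for them only; others in the source may bear on it.

For the measured compounds named here, in a functional assay on A-375 cells (Homo sapiens) for antiproliferative activity, read by MTT assay, with a stated time of 72 h (a lower number here means a stronger inhibitor, a higher number a weaker inhibitor), compound 1 (`COc1ccc(N2C(=O)COc3ccc(-c4cnc(Cl)c(NS(=O)(=O)c5ccc(F)cc5)c4)cc32)cc1`) gives 32700 nM and compound 2 (`COc1ncc(-c2ccc3c(c2)N(C2CC2)C(=O)CO3)cc1NS(=O)(=O)c1ccc(F)cc1`) gives 23900 nM as the only numbers so far. Compound 1 therefore stands level with compound 2, the two values lying within the scatter of each other. Compound 3 (`O=C1COc2ccc(-c3cnc(Cl)c(NS(=O)(=O)c4ccc(F)cc4)c3)cc2N1c1ccccc1`) differs from compound 1 by hydrogen in place of methoxy on an aromatic carbon, para to a large group, which reads as 4-methoxyphenyl to phenyl (hydrogen in place of methoxy on an aromatic carbon). Going by the values given here, no measured pair shows this change, so the series gives no direct size for it. With so little data, no step beyond the scatter is expected in this assay for this change. The estimated change is a 1.2-fold lower number from compound 1 to compound 3 (0.08 log units; within the scatter) and is expected to stay within the scatter. For compound 3 the estimated value is 27000 nM with an expected range of 11000 nM to 60000 nM as the working figures.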

Compound 3, half-maximal inhibitory concentration: 36900 nM
Estimate against measurement, compound 3: 1.4-fold (0.14 log units) below, within the range that was stated.
By their numbers in this assay, from the lowest: compounds 2, 1 and 3 (each within the scatter of the next).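

In this assay, for the compounds shown here, the change from 4-methoxyphenyl to phenyl gives a 1.1-fold higher number from compound 1 to compound 3 (0.05 log units; within the scatter) as the first direct reading of this replacement, so compound 1 and compound 3 stand level. Going by these compounds alone, on this one pair, hydrogen and methoxy on this aromatic carbon, para to a large group, are not separated, and both compounds remain in the same range as compound 2, which differs from them in more than one place and gives no step for this change. No supporting data bear on this result.

Going by these compounds, whether any group at this place moves the number beyond the scatter remains open, for example an amine or a carboxylic acid on the same aromatic carbon. Also open, on these data alone, is whether the level reading for hydrogen and methoxy holds on any core other than that of compound 1.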